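A Nitro-for-Fluoro Step on Two Anilino Positions

The source may hold more compounds than are shown below. What is called first, only, known or untested is meant among the compounds shown, and "the series" means these compounds.

Measured compounds:
compound 1, `CCN(CC)c1nc(Nc2cccc(F)c2)nc(OC(C(F)(F)F)C(F)(F)F)n1`, 140 nM
compound 2, `CCN(CC)c1nc(Nc2cccc([N+](=O)[O-])c2)nc(OC(C(F)(F)F)C(F)(F)F)n1`, 200 nM
compound 3, `CCN(CC)c1nc(Nc2ccc(F)cc2)nc(OC(C(F)(F)F)C(F)(F)F)n1`, 700 nM

Three compounds sharing one core have been characterised in an assay on cells for activation of Cystic fibrosis transmembrane conductance regulator (Homo sapiens), read by fluorescence, with stated times of 10 min and 12 s; on this read-out higher numbers stand for an effect only at larger amounts of compound and lower numbers for an effect already at smaller amounts. Compound 1, `CCN(CC)c1nc(Nc2cccc(F)c2)nc(OC(C(F)(F)F)C(F)(F)F)n1`, gives 140 nM, and compound 2, `CCN(CC)c1nc(Nc2cccc([N+](=O)[O-])c2)nc(OC(C(F)(F)F)C(F)(F)F)n1`, gives 200 nM. The difference between them is nitro in place of fluoro on an aromatic carbon, and the step is a 1.4-fold higher number from compound 1 to compound 2 (0.15 log units; within the scatter). Compound 3, `CCN(CC)c1nc(Nc2ccc(F)cc2)nc(OC(C(F)(F)F)C(F)(F)F)n1`, gives 700 nM. Compound 3 differs from compound 1 in how the same atoms are joined, (4-fluorophenyl in place of 3-fluorophenyl on a nitrogen on an aromatic ring), and the step is a 5.0-fold higher number from compound 1 to compound 3 (0.70 log units; beyond the scatter). From compound 2 to compound 3 the step is a 3.5-fold higher number from compound 2 to compound 3 (0.54 log units; beyond the scatter). Compound 3 thus has the highest number of the three, with both steps to it beyond the scatter.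

Compound 4, `CCN(CC)c1nc(Nc2ccc([N+](=O)[O-])cc2)nc(OC(C(F)(F)F)C(F)(F)F)n1`, has not been measured. It differs from compound 3 by nitro in place of fluoro on an aromatic carbon. This is the same kind of change as that from compound 1 to compound 2, though not the same: in the earlier pair the place is "meta to a large group", whereas here it is "para to a large group". The earlier step was small, a 1.4-fold higher number from compound 1 to compound 2 (0.15 log units; within the scatter), and the cores of compound 3 and compound 4 otherwise match those of compound 1 and compound 2 in every respect. Compound 4 is therefore expected to sit close to compound 3, with an estimated step of a 1.3-fold higher number from compound 3 to compound 4 (0.11 log units; within the scatter) in this assay, because the step of a 1.4-fold higher number from compound 1 to compound 2 (0.15 log units; within the scatter) stayed within the scatter. Going by the values given here, the estimate for compound 4 in this assay is 900 nM, with a range from 350 nM to 2500 nM, the width reflecting that only one instance of this kind of change has been measured and at a different place.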

Compound 4, half-maximal effective concentration: 18000 nM
Compound 4: the middle estimate sits 20-fold (1.30 log units) below what was measured; the whole stated range lies below it.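

In this assay, nitro in place of fluoro gives a 26-fold higher number from compound 3 to compound 4 (1.41 log units; beyond the scatter), 4-nitrophenyl in place of 3-nitrophenyl gives a 90-fold higher number from compound 2 to compound 4 (1.95 log units; beyond the scatter), and 4-nitrophenyl in place of 3-fluorophenyl gives a 130-fold higher number from compound 1 to compound 4 (2.11 log units; beyond the scatter). The step seen for nitro in place of fluoro on one core therefore did not carry over to the other: the same change on two cores in this assay, a 1.4-fold higher number (0.15 log units; within the scatter) from compound 1 to compound 2 and a 26-fold higher number (1.41 log units; beyond the scatter) from compound 3 to compound 4, 18-fold (1.26 log units) apart, beyond the scatter of two such steps This shows that, among these four compounds, the size of the step depends on where the change is made on the ring, but it rests on only two pairs and does not show the reason for the gap between them, nor does it give a rule for other places or cores.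

The compounds shown leave open whether so large a step belongs to nitro alone or would also appear with another group para to a large group, such as a nitrile, a carboxylic acid or a methoxy group. They also leave open whether the two steps would stay as far apart with a dimethylamino group on the shared core.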